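The source may hold more compounds than are shown below. What is called first, only, known or untested is meant among the compounds shown, and "the series" means these compounds.

Compound 1 `Cc1cnc(Nc2ccc([N+](=O)[O-])cc2)nc1Nc1nc2ccccc2s1`: in a functional assay on MDA-MB-231 cells (Homo sapiens) for antiproliferative activity, read by MTT assay, with a stated time of 48 h (on this read-out higher numbers stand for weaker inhibition and lower numbers for stronger inhibition), compound 1 gives 22500 nM.
Compound 2 `COc1cccc(Nc2ncc(C)c(Nc3nc4ccccc4s3)n2)c1`: in this assay compound 2 gives only a limit, > 50000 nM.
Compound 3 `COc1ccc(Nc2ncc(C)c(Nc3nc4ccccc4s3)n2)cc1`: in this assay compound 3 gives only a limit, > 50000 nM.

Compound 3 therefore stands at the limit of this assay, as does compound 2, which is recorded as the limit of > 50000 nM in this assay, at which 2 of the 3 values shown sit. Only compound 1 has a number, and the step of an at least 2.2-fold higher number from compound 1 to compound 3 (0.34 log units; beyond the scatter) shows that compound 3 is weaker than compound 1, though by an unknown margin. The step that the two limits leave unreadable from compound 2 to compound 3 between the two methoxyphenyl compounds cannot be read.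

Compound 4 `Cc1cnc(Nc2cccc(F)c2)nc1Nc1nc2ccccc2s1` differs from compound 3 by 3-fluorophenyl in place of 4-methoxyphenyl on a nitrogen on an aromatic ring. Among the measured compounds shown here, no measured step carries fluorine, so the change has no direct precedent; the steps that bear on it, an at least 2.2-fold higher number from compound 1 to compound 3 (0.34 log units; beyond the scatter) and a step that the two limits leave unreadable from compound 2 to compound 3, only say that the methoxy compounds reached the limit while the nitro compound did not. Compound 4 is therefore expected to sit near the limit, with a step of an at least 1.2-fold lower number from compound 3 to compound 4 (0.09 log units; that floor lies within the scatter) that cannot be called beyond the scatter. The estimate for compound 4 in this assay is 40000 nM, within 12000 nM to 100000 nM.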

Compound 4, half-maximal inhibitory concentration: > 50000 nM
Compound 4: only a limit was reported; the forecaster's own chance of this, stated with the estimate: 55%; at least 1.2-fold (0.09 log units) between middle value and limit.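

In this assay, among the compounds shown here, compound 4 also gives only a limit, > 50000 nM, so 3-fluorophenyl on a nitrogen on an aromatic ring joins the two methoxyphenyl groups at that limit: the limit of > 50000 nM in this assay, at which 3 of the 4 values shown sit. The one readable step, an at least 2.2-fold higher number from compound 1 to compound 4 (0.34 log units; beyond the scatter), places the fluoro compound on the same weaker side as the methoxy compounds, which leaves the 4-nitrophenyl group as the only one of the four that gives a number. The steps from compound 2 and from compound 3 to compound 4 cannot be read, as limits stand on both sides.

Going by these compounds, how far compound 2, compound 3 and compound 4 lie beyond the limit stays open, and with it whether fluoro and methoxy differ at all. Also open, on these data alone, is whether a nitrile or an amine in place of the nitro of the 4-nitrophenyl group would give a number in this assay.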